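Removing an Amino Group: Effect on Cell Growth Inhibition

The compounds below may be only part of what the source reports. "The series", "measured", "known", "first", "only" and "open" are said of these compounds alone.

Compound 1 `Nc1nc(Cl)c2ncn(Cc3ccccc3CCl)c2n1` was tested in a functional assay on DU-145 cells (Homo sapiens) for cytotoxicity, read by sulforhodamine B assay, with a stated time of 48 h (a higher number here means a weaker inhibitor of growth, a lower number a stronger inhibitor of growth), where compound 1 gives 14800 nM. Among the measured compounds shown here, that is the highest of the two numbers measured so far, so compound 1 is the weaker growth inhibitor of the pair. Compound 2 `ClCc1cccc(Cn2cnc3nc(Cl)nc(Cl)c32)c1` gives 140 nM in this assay, a far lower number, but compound 2 differs from compound 1 in more than one place, so that gap cannot be traced to any single change. Compound 3 `ClCc1ccccc1Cn1cnc2c(Cl)ncnc21` is not yet measured. Compound 3 differs from compound 1 by hydrogen in place of amino on an aromatic carbon. For the measured compounds named here, no measured pair shows this change on its own, so its size is open. In this assay the change is expected to give a moderate step toward a lower number, possibly beyond the scatter, a 3.7-fold lower number from compound 1 to compound 3 (0.57 log units; beyond the scatter). Compound 3 is therefore estimated at 4000 nM in this assay, within a range from 800 nM to 20000 nM.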

Compound 3, concentration for 50% growth inhibition: 5620 nM
Compound 3: middle estimate off by 1.4-fold (0.15 log units), on the low side; measured number inside the range.
By their numbers in this assay, from the lowest: compound 2; then compound 3; then compound 1.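

In this assay, among the compounds shown here, replacing the amino group with hydrogen gives a 2.6-fold lower number from compound 1 to compound 3 (0.42 log units; beyond the scatter), the first step here that can be traced to a single change. The amino group on this aromatic carbon, between two ring nitrogen atoms, is therefore not required for growth inhibition in these cells, and compound 3 remains active without it. No measurement available here explains why the number falls.

On these data alone, only amino and hydrogen can be compared directly at this position, so it remains open whether a methylamino, hydroxyl or methoxy group on the same carbon would lower the number further or raise it. As far as these compounds go, it is also open whether the same swap would give a step of similar size with the rest of the molecule changed.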